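Ethyl in place of methyl at the chiral carbon

A few compounds are considered here, and "the series" means these few. Any claim that something is new, unique, unknown or untested is made for them only; others in the source may bear on it.

Compounds measured so far in an assay for inhibition of serine/threonine-protein kinase PAK 1 (Homo sapiens), read by FRET and Z'-LYTE, with stated times of 10 min and 60 min; a lower number here means a stronger inhibitor, a higher number a weaker inhibitor:
compound 1 `c1cc(Nc2cc(C3CC3)[nH]n2)nc(NCc2ccc3[nH]ccc3n2)n1` gives 120 nM
compound 2 `C[C@H](Nc1nccc(Nc2cc(C3CC3)[nH]n2)n1)c1ccc2[nH]ccc2n1` gives 32 nM
compound 3 `C[C@H](Nc1nccc(Nc2cc(C3CC3)[nH]n2)n1)c1cc2cc[nH]c2cn1` gives 5 nM

Compound 2 holds the second highest of the three numbers in this assay. Its nearest neighbour is compound 1, with a 3.8-fold lower number from compound 1 to compound 2 (0.57 log units; beyond the scatter) separating them; the furthest is compound 3, reached by a 6.4-fold lower number from compound 2 to compound 3 (0.81 log units; beyond the scatter). Compound 4 `CC[C@H](Nc1nccc(Nc2cc(C3CC3)[nH]n2)n1)c1ccc2[nH]ccc2n1` has not yet been measured. It differs from compound 2 by methyl in place of hydrogen on a saturated chain carbon, two bonds along the chain from an aromatic carbon and a nitrogen on an aromatic ring. For the measured compounds named here, the only measured step that touches the same chain carbon is the one from compound 1 to compound 2, where adding the first methyl lowered the number beyond the scatter. Whether a second methyl, making ethyl, continues that movement is not shown by any measured pair, so the expected change is small. The estimated step is a 1.3-fold lower number from compound 2 to compound 4 (0.11 log units; within the scatter), a slight lowering that may well fall within the scatter. For compound 4 the expected value in this assay is 25 nM, with a range from 8 nM to 80 nM.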

Compound 4, inhibition constant: 23 nM
Compound 4: the middle estimate sits 1.1-fold (0.04 log units) above what was measured; low and high end bracket the measured number.
By their numbers in this assay, from the lowest: compound 3; then compounds 4 and 2 (each within the scatter of the next); then compound 1.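

In this assay, lengthening methyl to ethyl on this saturated chain carbon gives a 1.4-fold lower number from compound 2 to compound 4 (0.14 log units; within the scatter), so the two values cannot be told apart and the chain carbon takes the extra carbon with no measurable change. Ethyl in place of hydrogen at the same carbon remains a step beyond the scatter, a 5.2-fold lower number from compound 1 to compound 4 (0.72 log units; beyond the scatter), so the difference from the hydrogen compound survives the longer group. Nothing available explains this result.

The compounds shown leave open whether a propyl chain, or an amine carried on this carbon, would keep the number in the same range. They also leave open whether ethyl would behave the same way on the core of compound 3, which gives 5 nM.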